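Swapping anilino for morpholin-4-yl on the carbonyl carbon

The compounds below may be only part of what the source reports. "The series", "measured", "known", "first", "only" and "open" are said of these compounds alone.

Compound 2 `O=C([C@@H]1CCCN1C(=O)Nc1ccccc1)N1CCC(NS(=O)(=O)c2cc(S(=O)(=O)c3ccccc3)ccc2C(F)(F)F)CC1` gives 20 nM in an assay on isolated protein for binding affinity to secreted frizzled-related protein 1 (Homo sapiens), read by fluorescence (a lower number here means a stronger inhibitor, a higher number a weaker inhibitor), the lower of the two numbers measured, while compound 1 `CC(C)(C)OC(=O)N1CCC[C@H]1C(=O)N1CCC(NS(=O)(=O)c2cc(S(=O)(=O)c3ccccc3)ccc2C(F)(F)F)CC1` gives 60 nM, and the step of a 3.0-fold lower number from compound 1 to compound 2 (0.48 log units; beyond the scatter) is the only one recorded. Compound 3 `O=C([C@@H]1CCCN1C(=O)N1CCOCC1)N1CCC(NS(=O)(=O)c2cc(S(=O)(=O)c3ccccc3)ccc2C(F)(F)F)CC1` differs from compound 2 by morpholin-4-yl in place of anilino on a carbonyl carbon. Among the measured compounds shown here, that earlier step changed the same carbonyl carbon but installed a different group, so it bears on this change only loosely, and no measured step covers morpholin-4-yl. The expected step is a 2.0-fold higher number from compound 2 to compound 3 (0.30 log units; within the scatter), small and pointing toward a higher number. Compound 3 is therefore expected to give 40 nM, within a range from 15 nM to 120 nM.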

Compound 3, half-maximal inhibitory concentration: 40 nM
The estimate for compound 3 equals the measured number at the digits printed, and the stated range covers the measured number.
By their numbers in this assay, from the lowest: compounds 2, 3 and 1 (each within the scatter of the next, the first and the last beyond it).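

In this assay, morpholin-4-yl on this carbonyl carbon gives a 2.0-fold higher number from compound 2 to compound 3 (0.30 log units; within the scatter), so replacing anilino, with its aromatic ring and hydrogen-bond donor, leaves no difference beyond the scatter. The other new comparison is a 1.5-fold lower number from compound 1 to compound 3 (0.18 log units; within the scatter), also within the scatter. Compound 3 therefore cannot be separated from either compound 1 or compound 2, even though those two differ beyond the scatter.

As far as these compounds go, whether piperidin-1-yl or dimethylamino on the same carbonyl carbon would read alike remains open. No measurement shown gives a reason for these readings.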